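Adding Isopropyl to the Amide of Compound 1

This account rests on a few compounds, and the source may have more. Where it says the series, first, only, none or still open, it means among the compounds named here.

Compound 1 `CC[C@@H]1C(=O)N(C)c2cnc(-n3ccc4cc(C(N)=O)ccc43)nc2N1C1CCCC1` gives 674 nM as its value
Compound 2 `CCC1C(=O)N(C)c2cnc(-n3ccc4cc(F)ccc43)nc2N1c1ccn(C)n1` gives "not active" (no number reported) as its result

For the measured compounds named here, in a functional assay on HeLa cells (Homo sapiens) for antiproliferative activity, read by CCK-8 assay, with a stated time of 72 h (a lower number here means a stronger inhibitor of growth, a higher number a weaker inhibitor of growth), compound 1 gives 674 nM and holds the only number so far, so it cannot be ranked against a series. Compound 2 gives "not active" (no number reported) with no figure attached, which leaves nothing to compare numerically.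

Compound 3 `CC[C@@H]1C(=O)N(C)c2cnc(-n3ccc4cc(C(=O)NC(C)C)ccc43)nc2N1C1CCCC1` keeps the core of compound 1 and changes one place: isopropyl in place of hydrogen on an amide-type nitrogen with isopropyl in place of hydrogen on an amide-type nitrogen, so carbamoyl becomes isopropylcarbamoyl. Going by the values given here, no measured step shows what this change does, so any forecast is loose. A modest weakening in this assay is expected, possibly not much beyond the usual scatter, and the estimated move is a 1.5-fold higher number from compound 1 to compound 3 (0.17 log units; within the scatter) in size. Compound 3 is estimated at 1000 nM with an expected range from 250 nM to 5000 nM for its value.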

Compound 3, concentration for 50% growth inhibition: 292 nM
Compound 3: middle estimate off by 3.4-fold (0.53 log units), on the high side; low and high end bracket the measured number.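

In this assay, replacing a hydrogen with isopropyl on the amide-type nitrogen gives a 2.3-fold lower number from compound 1 to compound 3 (0.36 log units; beyond the scatter), a modest step that lies beyond the scatter and points towards stronger growth inhibition. For the compounds shown here, this is the first reading at this position, and it shows that the position accepts isopropyl with no loss of activity, so carbamoyl is not required for activity at this level. The compounds shown offer no measurement that explains the gain.

Going by these compounds, a single step cannot show a trend, so it stays open whether methyl, a longer chain such as butyl, or a chain ending in an amine on the same nitrogen would lower the number further or raise it again. On these data alone, whether isopropylcarbamoyl gives a similar step on a different core also stays open.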